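The source may hold more compounds than are shown below. What is called first, only, known or untested is meant among the compounds shown, and "the series" means these compounds.

In a physicochemical assay for solubility, with a stated time of 24 h, at pH 6.8 (on this read-out higher numbers stand for higher solubility and lower numbers for lower solubility), compound 1, `COC(=O)c1ccc2ccc(C(=O)c3ccccc3)c-2cc1`, gives < 1 ug/mL, which is a limit and not a number. Compound 2, `O=C(NCc1cccnc1)c1ccc2ccc(C(=O)c3ccccc3)c-2cc1`, gives < 1 ug/mL in this assay, and this too is a limit. Among the compounds with values here, the series so far therefore comes down to the limit of < 1 ug/mL in this assay, at which 2 of the 2 values shown sit, and compound 2 has no readable place within it.

Compound 3, `O=C(NCCO)c1ccc2ccc(C(=O)c3ccccc3)c-2cc1`, keeps the shared core and the amide but has 2-hydroxyethyl where compound 2 has (pyridin-3-yl)methyl. The change is hydroxymethyl in place of pyridin-3-yl on a saturated chain carbon bound to an amide-type nitrogen.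

Within the data shown here, only one measured step bears on this, a step that the two limits leave unreadable from compound 1 to compound 2, and it offers no size to carry over. It also concerns a different exchange, on a carbonyl carbon. The expectation thus starts from a limit, < 1 ug/mL for compound 2, and rests otherwise on the structural change alone. The expected step of an at least 2.0-fold higher number from compound 2 to compound 3 (0.30 log units; that floor lies within the scatter) is small and upward, and the reading may well stay at the limit. For compound 3 the estimated solubility in this assay is 2 ug/mL, with an expected range from 0.5 ug/mL to 10 ug/mL.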

Compound 3, solubility: 4 ug/mL
Beside the measured number, compound 3's estimate is 2.0-fold (0.30 log units) below it; low and high end bracket the measured number.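

In this assay, within the data shown here, hydroxymethyl in place of pyridin-3-yl on a saturated chain carbon bound to an amide-type nitrogen gives an at least 4.0-fold higher number from compound 2 to compound 3 (0.60 log units; beyond the scatter), the first step with a readable size. This step starts from a limit. It gives only a floor. The exchange on the carbonyl carbon, unreadable with ((pyridin-3-yl)methyl)amino in place of methoxy, also becomes readable with (2-hydroxyethyl)amino in place of methoxy, which gives an at least 4.0-fold higher number from compound 1 to compound 3 (0.60 log units; beyond the scatter), so the amide alone does not account for the step, since compound 2 also carries one. Compound 3 is the only compound of the three that stands clear of the limit: the limit of < 1 ug/mL in this assay, at which 2 of the 3 values shown sit.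

The exchange removes a six-membered aromatic ring and brings in a hydrogen-bond donor in a single change, and the compounds shown do not separate these two differences. On these data alone, how an amide carrying a plain ethyl group, a longer chain ending in hydroxyl, an amine or a carboxylic acid would read at this position remains open, as does the true size of both steps.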